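This account rests on a few compounds, and the source may have more. Where it says the series, first, only, none or still open, it means among the compounds named here.

Measured so far in a functional assay on UACC-62 cells (Homo sapiens) for inhibition, read by sulforhodamine B assay, with a stated time of 48 h; a lower number here means a stronger inhibitor of growth, a higher number a weaker inhibitor of growth:
- compound 1 `CN1CCCN(CCNc2nccc(-c3c(-c4cccc(O)c4)nc4sccn34)n2)S1(=O)=O`: 3140 nM
- compound 2 `O=S(=O)(NCCCNc1nccc(-c2c(-c3cccc(O)c3)nc3sccn23)n1)c1cccc(F)c1`: 2730 nM

Among the measured compounds shown here, compound 2 cannot be told apart from compound 1, the only other measured compound, as the numbers show a 1.2-fold lower number from compound 1 to compound 2 (0.06 log units; within the scatter).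

Compound 3 `O=S(=O)(NCCNc1nccc(-c2c(-c3cccc(O)c3)nc3sccn23)n1)c1ccc(F)cc1` differs from compound 2 at one place, on a saturated chain carbon, two bonds along the chain from a nitrogen on an aromatic ring: ((4-fluorophenyl)sulfonyl)amino in place of (((3-fluorophenyl)sulfonyl)amino)methyl on a saturated chain carbon, two bonds along the chain from a nitrogen on an aromatic ring. For the measured compounds named here, only one measured step bears on this place. That step, a 1.2-fold lower number from compound 1 to compound 2 (0.06 log units; within the scatter), exchanged two quite different groups there and stayed within the scatter. Going by the values given here, no measured pair tests the present change alone, so the evidence is thin, but no step beyond the scatter is expected in this assay. The estimated step is a 1.0-fold higher number from compound 2 to compound 3 (0.01 log units; within the scatter). Compound 3 is expected at 2800 nM, with an estimated range of 1300 nM to 6000 nM.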

Compound 3, concentration for total growth inhibition: 10300 nM
Estimate against measurement, compound 3: 3.7-fold (0.57 log units) below; the whole stated range lies below it.
By their numbers in this assay, from the lowest: compounds 2 and 1 (each within the scatter of the next); then compound 3.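

In this assay, among the compounds shown here, this position is no longer silent: ((4-fluorophenyl)sulfonyl)amino in place of (((3-fluorophenyl)sulfonyl)amino)methyl gives a 3.8-fold higher number from compound 2 to compound 3 (0.58 log units; beyond the scatter), and the same group in place of the one in compound 1 gives a 3.3-fold higher number from compound 1 to compound 3 (0.52 log units; beyond the scatter), whereas the earlier exchange here gave only a 1.2-fold lower number from compound 1 to compound 2 (0.06 log units; within the scatter). The groups at this place are therefore not all interchangeable, even though the two that leave differ widely from each other and the group that enters closely resembles (((3-fluorophenyl)sulfonyl)amino)methyl. No measurement shown here accounts for this step.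

Going by these compounds, the change combines the loss of the methyl link with the move from 3-fluorophenyl to 4-fluorophenyl, so it remains open which of the two matters, and ((3-fluorophenyl)sulfonyl)amino at this place would separate them. On these data alone, how an amine or a carboxylic acid would behave here also remains open.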